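The source may hold more compounds than are shown below. What is called first, only, known or untested is meant among the compounds shown, and "the series" means these compounds.

Measured in an ADME assay on microsomes from liver (Mus musculus) for metabolic stability, read by HPLC, using NADPH, with a stated time of 60 min, tested at 1 uM, in the presence of a further agent that is not named here; on this read-out higher numbers stand for a longer-lived compound and lower numbers for a shorter-lived compound:
- compound 1 `Cc1cc(-c2ncccn2)cc(C(=O)NNS(=O)(=O)c2ccccc2)c1F`: 0.1 h
- compound 2 `Cc1cc(-c2ccccn2)cc(C(=O)NNS(=O)(=O)c2ccccc2)c1F`: 0.0667 h

Compound 2, at 0.0667 h, stands within the scatter of compound 1, so these two numbers give no order. Compound 3 `Cc1cc(-n2nccn2)cc(C(=O)NNS(=O)(=O)c2ccccc2)c1F` is not yet measured. It carries 2H-1,2,3-triazol-2-yl in place of pyridin-2-yl on an aromatic carbon, para to a fluoro group: 2H-1,2,3-triazol-2-yl in place of pyridin-2-yl on an aromatic carbon. Within the data shown here, only one measured step bears on this place, a 1.5-fold lower number from compound 1 to compound 2 (0.18 log units; within the scatter), an exchange of pyrimidin-2-yl for pyridin-2-yl. Among the measured compounds shown here, no measured compound carries a five-membered aromatic ring there, so this guide is thin. On that single step, no change beyond the scatter is expected in this assay. The expected step is a 1.3-fold higher number from compound 2 to compound 3 (0.13 log units; within the scatter). For compound 3 the estimated half-life is 0.09 h, with an expected range of 0.04 h to 0.2 h.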

Compound 3, half-life in the Mus musculus assay: 0.0333 h
Beside the measured number, compound 3's estimate is 2.7-fold (0.43 log units) above it, and the stated range ends above it.
By their numbers in the Mus musculus assay, from the lowest: compounds 3, 2 and 1 (each within the scatter of the next, the first and the last beyond it).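

Among these compounds, in the Mus musculus assay compound 3 gives 0.0333 h, and its 2H-1,2,3-triazol-2-yl gives the first step at this aromatic carbon that leaves the scatter, a 3.0-fold lower number from compound 1 to compound 3 (0.48 log units; beyond the scatter), whereas the comparison with pyridin-2-yl, a 2.0-fold lower number from compound 2 to compound 3 (0.30 log units; within the scatter), stays within it, so a five-membered aromatic ring separates from pyrimidin-2-yl only. In a physicochemical assay for solubility, read by nephelometry, measured as kinetic solubility, at pH 2 (a lower number here means a less soluble compound, a higher number a more soluble compound), compound 2 gives 50 ug/mL and compound 3 gives 25 ug/mL. In the physicochemical assay the same exchange gives a 2.0-fold lower number from compound 2 to compound 3 (0.30 log units; within the scatter), which also stays within the scatter and sets no order between these two compounds. Nothing at hand offers an explanation for these numbers.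

On these data alone, whether an amine or a carboxylic acid at this place, in place of an aromatic ring, would move the half-life stays open. So does how 2H-1,2,3-triazol-2-yl compares with a five-membered aromatic ring carrying fewer nitrogen atoms.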